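This account rests on a few compounds, and the source may have more. Where it says the series, first, only, none or still open, it means among the compounds named here.

Among the compounds with values here, compound 1 (`Cn1c(N)c(C#N)c2cc(OCc3cccc(NC(=O)C(N)CO)c3)ccc21`) is the only compound here with a numerical result: in an assay on isolated protein for inhibition of arsenite methyltransferase (Homo sapiens), with stated times of 30 min and 90 min, in the presence of a further agent that is not named here (on this read-out lower numbers stand for stronger inhibition and higher numbers for weaker inhibition), compound 1 gives 2900 nM. Compound 2 (`CC(C)(C)C(=O)Nc1[nH]c2ccc(OCc3ccccc3)cc2c1C#N`) belongs to a different case, namely (the limit of > 100000 nM in this assay, at which 1 of the 2 values shown sits). In this assay compound 2 is reported as > 100000 nM, which is a limit of the assay and not a number. Within the data shown here, no two measured compounds differ in a single place, so no measured step exists to guide the next change. Compound 3 (`Cn1c(N)c(C#N)c2cc(OCc3cccc(N)c3)ccc21`) differs from compound 1 by hydrogen in place of (1-amino-2-hydroxyethyl)carbonyl on a nitrogen on an aromatic ring, so the amide is cut back to a bare amino group. Without a measured step of this kind to lean on, a modest weakening is expected, a 2.1-fold higher number from compound 1 to compound 3 (0.32 log units; beyond the scatter), a step that may still fall within the ordinary scatter. Compound 3 is therefore estimated at 6000 nM, with a likely range from 2000 nM to 20000 nM.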

Compound 3, half-maximal inhibitory concentration: 1400 nM
Compound 3: the middle estimate sits 4.3-fold (0.63 log units) above what was measured; measured number below the stated range.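

Cutting the (1-amino-2-hydroxyethyl)carbonyl group back to hydrogen on this nitrogen gives the first single-change comparison in this assay: a 2.1-fold lower number from compound 1 to compound 3 (0.32 log units; beyond the scatter). The shared core therefore keeps its inhibition without this group, and the plain amino group does modestly better than the larger amide. Nothing measured here explains why the number fell.

Going by these compounds, it remains open whether any group on this nitrogen can improve on the plain amino group, for example a small acetyl amide, a methyl group or a longer chain ending in a carboxylic acid. On these data alone, it is also open whether the same change would have a similar effect on another core, as this single pair offers no test of that.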